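This account rests on a few compounds, and the source may have more. Where it says the series, first, only, none or still open, it means among the compounds named here.

Compound 1 `OC[C@H]1O[C@@H](n2cnc3c(CSCc4ccccc4)ncnc32)[C@H](O)[C@@H]1O` carries a benzylsulfanyl group on a saturated chain carbon of the shared core. In a functional assay on Huh-7 cells (Homo sapiens) for cytotoxicity, read by MTT assay, with a stated time of 3 days (a lower number here means that less compound is tolerated, a higher number that more compound is tolerated), compound 1 gives > 100000 nM, which is a limit of the assay rather than a measured number. Compound 2 `OC[C@H]1O[C@@H](n2cnc3c(COc4ccccc4)ncnc32)[C@H](O)[C@@H]1O`, with phenoxy in that place, gives > 100000 nM in this assay, again a limit. Compound 3 `O=C(O)CNCc1ncnc2c1ncn2[C@@H]1O[C@H](CO)[C@@H](O)[C@H]1O`, carrying (carboxymethyl)amino there, gives > 100000 nM, also a limit. The steps a step that the two limits leave unreadable from compound 1 to compound 2, a step that the two limits leave unreadable from compound 1 to compound 3 and a step that the two limits leave unreadable from compound 2 to compound 3 therefore cannot be read, because of the limit of > 100000 nM in this assay, at which 3 of the 3 values shown sit. Compound 4 `OC[C@H]1O[C@@H](n2cnc3c(CSc4nc5ccccc5s4)ncnc32)[C@H](O)[C@@H]1O` differs from compound 1 by 1,3-benzothiazol-2-yl in place of benzyl on a sulfur. For the measured compounds named here, no measured step puts a number on such a change; the three measured compounds only show that varying the group on that saturated chain carbon left each of them at the same limit. Compound 4 is therefore expected to sit at that limit as well, a step of a number no higher from compound 1 to compound 4 (the limit leaves the size open) of no readable size. The estimate for compound 4 is 100000 nM, with a range from 40000 nM to 300000 nM.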

Compound 4, half-maximal cytotoxic concentration: > 100000 nM
Compound 4 was reported as a limit; the forecaster's own chance of this, stated with the estimate: 85%; the middle value sits exactly at the limit.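

Compound 4, like compound 1, sits at a limit, so no size can be read for the change from benzyl to 1,3-benzothiazol-2-yl on the sulfur: the limit of > 100000 nM in this assay, at which 4 of the 4 values shown sit. The compounds shown leave open whether the group on that saturated chain carbon changes how much compound is tolerated in this assay.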